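Swapping 4-methylphenyl for 2-methoxyphenyl on a shared core

The compounds below may be only part of what the source reports. "The series", "measured", "known", "first", "only" and "open" are said of these compounds alone.

Measured in a functional assay on CCRF-CEM cells (Homo sapiens) for antiproliferative activity, with a stated time of 72 h; on this read-out lower numbers stand for stronger inhibition and higher numbers for weaker inhibition:
- Compound 1 `OC[C@H]1O[C@@H](n2cnc3c(NCc4ccccc4F)ncnc32)[C@H](O)[C@@H]1O`: 4600 nM
- Compound 2 `OC[C@H]1O[C@@H](n2cnc3c(NCc4ccc(F)cc4)ncnc32)[C@H](O)[C@@H]1O`: 1250 nM
- Compound 3 `Cc1ccc(CNc2ncnc3c2ncn3[C@@H]2O[C@H](CO)[C@@H](O)[C@H]2O)cc1`: > 166000 nM (a limit of the assay, not a number)

Compound 3 has no exact value, only a limit: the limit of > 166000 nM in this assay, at which 1 of the 3 values shown sits. Compound 4 `COc1ccccc1CNc1ncnc2c1ncn2[C@@H]1O[C@H](CO)[C@@H](O)[C@H]1O` keeps the same core and has 2-methoxyphenyl in place of 4-methylphenyl on a saturated chain carbon bound to a nitrogen on an aromatic ring. The new group brings one hydrogen-bond acceptor.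

For the measured compounds named here, no measured step makes this exact swap, so the nearest evidence must serve. Two steps also start from a different group and end at the 4-methylphenyl of compound 3, and both are large: an at least 36-fold higher number from compound 1 to compound 3 (1.55 log units; beyond the scatter) and an at least 130-fold higher number from compound 2 to compound 3 (2.12 log units; beyond the scatter). The two fluorinated compounds differ far less: a 3.7-fold lower number from compound 1 to compound 2 (0.57 log units; beyond the scatter). Compound 4 gives up the 4-methylphenyl group, so a clear move to a lower number is expected in this assay, though probably not all the way to the fluorinated pair. The expected size of the change is an at least 8.3-fold lower number from compound 3 to compound 4 (0.91 log units; beyond the scatter). For compound 4 the estimated value is 20000 nM, with an expected range from 3000 nM to 166000 nM.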

Compound 4, half-maximal inhibitory concentration: 3200 nM
Compound 4: the middle estimate sits 6.3-fold (0.80 log units) above what was measured, and the stated range covers the measured number.
By their numbers in this assay, from the lowest: compound 2; then compounds 4 and 1 (each within the scatter of the next). At a limit, above all of these: compound 3.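

In this assay, 2-methoxyphenyl in place of 4-methylphenyl on the saturated chain carbon gives an at least 51-fold lower number from compound 3 to compound 4 (1.71 log units; beyond the scatter), so a group without fluorine can sit here and still give a measured number. Compound 3 has only a limit, so that step gives a minimum size and not an exact one: the limit of > 166000 nM in this assay, at which 1 of the 4 values shown sits. Methoxy in place of fluoro on the aromatic carbon stays within the usual scatter, with a 1.4-fold lower number from compound 1 to compound 4 (0.16 log units; within the scatter), while 2-methoxyphenyl in place of 4-fluorophenyl is a modest change, with a 2.6-fold higher number from compound 2 to compound 4 (0.41 log units; beyond the scatter).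

On these data alone, compound 3 and compound 4 differ in both the group on the phenyl ring and where it sits, so it remains open which of the two matters; 2-methylphenyl and 4-methoxyphenyl on the same carbon would separate them. Also open, as far as these compounds go, is how a phenyl ring carrying an amine or a carboxylic acid would read in this assay.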